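The source may hold more compounds than are shown below. What is called first, only, known or untested is meant among the compounds shown, and "the series" means these compounds.

Of the compounds shown here, three that share one core have so far been tested in an assay on isolated protein for inhibition of bone morphogenetic protein 1 (Homo sapiens); on this read-out higher numbers stand for weaker inhibition and lower numbers for stronger inhibition. Compound 1 `COc1ccc(S(=O)(=O)N(Cc2cccc(Br)c2)[C@H](C)C(=O)NO)cc1` gives 93 nM. Compound 2 `COc1ccc(S(=O)(=O)N(Cc2cc(F)cc(F)c2)[C@H](C)C(=O)NO)cc1` gives 140 nM, and compound 3 `COc1ccc(S(=O)(=O)N(Cc2cnc(Cl)s2)[C@H](C)C(=O)NO)cc1` gives 180 nM. Of these three numbers compound 3 carries the largest, but it does not stand apart from the others, since both steps that lead to it stay within the scatter: a 1.3-fold higher number from compound 2 to compound 3 (0.11 log units; within the scatter) and a 1.9-fold higher number from compound 1 to compound 3 (0.29 log units; within the scatter). The step between the first two compounds is likewise small: a 1.5-fold higher number from compound 1 to compound 2 (0.18 log units; within the scatter).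

Compound 4 `COc1ccc(S(=O)(=O)N(Cc2ccc(Br)cc2)[C@H](C)C(=O)NO)cc1` has not yet been measured. Compared with compound 3 the change is 4-bromophenyl in place of 2-chloro-1,3-thiazol-5-yl on a saturated chain carbon bound to a sulfonamide nitrogen. Every swap of this group seen so far, whether a bromophenyl for a difluorophenyl or either of these for the chlorothiazolyl, moved the number by less than the scatter. A bromophenyl is already present in compound 1, with its bromine at a different position, and the step of a 1.9-fold higher number from compound 1 to compound 3 (0.29 log units; within the scatter) to the chlorothiazolyl was small. Going back to a bromophenyl is therefore expected to give at most a modest shift, with the number expected to drift a little downward, that is a 1.6-fold lower number from compound 3 to compound 4 (0.21 log units; within the scatter). For compound 4 the estimate in this assay is 110 nM, in a range from 40 nM to 300 nM.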

Compound 4, half-maximal inhibitory concentration: 37 nM
The estimate for compound 4 lay 3.0-fold (0.47 log units) above the measured number, outside the stated range (below it).
By their numbers in this assay, from the lowest: compound 4; then compounds 1, 2 and 3 (each within the scatter of the next).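

In this assay, going by these compounds alone, swaps of this group on a saturated chain carbon bound to a sulfonamide nitrogen had so far stayed within the scatter, which made the position look forgiving, but 4-bromophenyl is the first group to break that picture: the result is a 4.9-fold lower number from compound 3 to compound 4 (0.69 log units; beyond the scatter) when it replaces 2-chloro-1,3-thiazol-5-yl and a 3.8-fold lower number from compound 2 to compound 4 (0.58 log units; beyond the scatter) when it replaces 3,5-difluorophenyl. The closest comparison is a 2.5-fold lower number from compound 1 to compound 4 (0.40 log units; beyond the scatter), where the ring and its single bromine stay the same and only the change from 3-bromophenyl to 4-bromophenyl separates the two compounds, so the place of the bromine on this ring matters in this assay. With all three of its steps beyond the scatter, compound 4 is the most potent of the four, but no supporting data are available to explain the gain.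

Going by these compounds, it remains open whether the gain belongs to bromine itself or would also appear with another group in the same ring place, such as 4-chlorophenyl or 4-methylphenyl. Also open, on these data alone, is whether a longer chain bound to the sulfonamide nitrogen and ending in the same 4-bromophenyl would keep the lower number.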